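A few compounds are considered here, and "the series" means these few. Any claim that something is new, unique, unknown or untested is made for them only; others in the source may bear on it.

Working notes on the series.

Compound 1 `CC(C(=O)NCc1ccc(C(F)(F)F)cc1F)c1ccc(NS(C)(=O)=O)c(F)c1` gives 68.7 nM in an assay on CHO cells for antagonist activity at transient receptor potential cation channel subfamily V member 1 (Homo sapiens), read by FLIPR; on this read-out higher numbers stand for weaker inhibition and lower numbers for stronger inhibition. Compound 2 `CC(C(=O)NCc1ccc(C(F)(F)F)cc1Cl)c1ccc(NS(C)(=O)=O)c(F)c1` gives 4 nM, and compound 3 `CC(C(=O)NCc1ccc(C(F)(F)F)cc1-c1cccc(F)c1)c1ccc(NS(C)(=O)=O)c(F)c1` gives 1.9 nM, the lowest of the three numbers. The change from compound 1 to compound 2 is chloro in place of fluoro on an aromatic carbon, and it gave a 17-fold lower number from compound 1 to compound 2 (1.23 log units; beyond the scatter). The change from compound 1 to compound 3 is 3-fluorophenyl in place of fluoro on an aromatic carbon, giving a 36-fold lower number from compound 1 to compound 3 (1.56 log units; beyond the scatter); between the two, a 2.1-fold lower number from compound 2 to compound 3 (0.32 log units; beyond the scatter).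

Compound 4 `CC(C(=O)NCc1ccc(C(F)(F)F)cc1-c1cccc(Cl)c1)c1ccc(NS(C)(=O)=O)c(F)c1` is not yet measured. Its difference from compound 3 is chloro in place of fluoro on an aromatic carbon. This is the same kind of change as from compound 1 to compound 2, but the place differs: there it sat ortho to a large group and meta to a trifluoromethyl group, here it sits meta to a large group on the 3-fluorophenyl ring, so the earlier step is only a rough guide. Compound 4 is expected at 1.3 nM, a step of a 1.5-fold lower number from compound 3 to compound 4 (0.16 log units; within the scatter) that is expected to be smaller than a 17-fold lower number from compound 1 to compound 2 (1.23 log units; beyond the scatter) since compound 3 already stands at 1.9 nM.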

Compound 4, inhibition constant: 1 nM
Compound 4: middle estimate off by 1.3-fold (0.11 log units), on the high side, and the stated range covers the measured number.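

In this assay, chloro in place of fluoro does not carry from one core to another at a constant size: the same change on two cores in this assay, a 17-fold lower number (1.23 log units; beyond the scatter) from compound 1 to compound 2 and a 1.9-fold lower number (0.28 log units; within the scatter) from compound 3 to compound 4, 9.0-fold (0.96 log units) apart, beyond the scatter of two such steps. The new step, a 1.9-fold lower number from compound 3 to compound 4 (0.28 log units; within the scatter), leaves compound 3 and compound 4 level within the scatter, while 3-chlorophenyl in place of a ring halogen still gives a 4.0-fold lower number from compound 2 to compound 4 (0.60 log units; beyond the scatter) and a 69-fold lower number from compound 1 to compound 4 (1.84 log units; beyond the scatter). These two pairs show that the size of this change is not transferable here, but they differ in both core and place, so they neither separate those two factors nor give a general rule.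

Left open is how a nitrile or a methoxy group in place of the chloro of the 3-chlorophenyl group would read. Also open, from the compounds shown here alone, is whether an amine in place of the whole 3-chlorophenyl group would hold the number of compound 4.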